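Hydroxy removal from the chain of compound 2

The source may hold more compounds than are shown below. What is called first, only, known or untested is meant among the compounds shown, and "the series" means these compounds.

Measured in a functional assay on A549 cells (Homo sapiens) for cytotoxicity; a lower number here means a stronger inhibitor, a higher number a weaker inhibitor:
- compound 1 `C=C/C=C\[C@H](C)[C@H](OC(N)=O)[C@@H](C)[C@H](O)[C@@H](C)C/C(C)=C\[C@H](C)[C@H]1OC(=O)C=C[C@@H]1C`: 6770 nM
- compound 2 `CCCC[C@H](C)[C@H](OC(N)=O)[C@@H](C)[C@H](O)[C@@H](C)C/C(C)=C\[C@H](C)[C@@H](O)[C@@H](C)CC[C@@H](O)C[C@@H]1OC(=O)[C@H](C)[C@@H](O)[C@H]1C`: 67.7 nM
- compound 3 `CCCC[C@H](C)[C@H](OC(N)=O)[C@@H](C)[C@H](O)[C@@H](C)C/C(C)=C\[C@H](C)[C@@H](O)[C@@H](C)/C=C\[C@@H](O)C[C@@H]1OC(=O)[C@H](C)[C@@H](O)[C@H]1C`: 8.4 nM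

Among these three, compound 2 holds the middle place, with compound 3 lower and compound 1 higher, both gaps beyond the scatter. Compound 4 `CCCC[C@H](C)[C@H](OC(N)=O)[C@@H](C)[C@H](O)[C@@H](C)C/C(C)=C\[C@H](C)[C@@H](O)[C@@H](C)CCCC[C@@H]1OC(=O)[C@H](C)[C@@H](O)[C@H]1C` differs from compound 2 by hydrogen in place of hydroxy on a saturated chain carbon bound to two saturated chain carbons. Going by the values given here, no measured pair isolates this change, so its size in this assay is a judgement. A modest weakening, slightly beyond the scatter, is expected. The expected step is a 1.9-fold higher number from compound 2 to compound 4 (0.28 log units; within the scatter). Compound 4 is estimated at 130 nM, with a range of 35 nM to 500 nM.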

Compound 4, half-maximal inhibitory concentration: 377 nM
The estimate for compound 4 lay 2.9-fold (0.46 log units) below the measured number; measured number inside the range.
By their numbers in this assay, from the lowest: compound 3; then compound 2; then compound 4; then compound 1.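

In this assay, hydrogen in place of hydroxy on a saturated chain carbon bound to two saturated chain carbons gives a 5.6-fold higher number from compound 2 to compound 4 (0.75 log units; beyond the scatter). Going by these compounds alone, this is the first reading that isolates this position, and it shows that the hydroxy contributes to potency here, since nothing else changes and the loss lies beyond the scatter. Nothing available explains the loss.

The compounds shown leave open whether an amine, a methoxy group or fluorine on this carbon would keep the potency of compound 2. Also open, as far as these compounds go, is whether the same removal costs as much in the chain of compound 3.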